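Cyclopropylmethoxy to methoxy: expected step for compound 4

The source may hold more compounds than are shown below. What is called first, only, known or untested is meant among the compounds shown, and "the series" means these compounds.

In a functional assay on SH-SY5Y cells (Homo sapiens) for antiproliferative activity, read by MTT assay, with a stated time of 48 h (on this read-out lower numbers stand for stronger inhibition of growth and higher numbers for weaker inhibition of growth), compound 2 (`COc1ccccc1OCCNc1ccc(=O)n(Cc2ccc(OC)c(OCC3CC3)c2)n1`) gives 10500 nM as the reference point for this step. Compound 3 (`COc1ccccc1OCCNc1ccc(=O)n(Cc2ccc(OC(F)F)c(OCC3CC3)c2)n1`) gives 6300 nM and lies within the scatter of compound 2. Going by the values given here, compound 1 (`COc1ccc(Cn2ncc(NCCOc3ccccc3OC)c(Cl)c2=O)cc1OC`) gives 33100 nM and is the one number clearly higher than that of compound 2.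

Compound 4 (`COc1ccc(Cn2nc(NCCOc3ccccc3OC)ccc2=O)cc1OC`) has not yet been measured. Relative to compound 2 the change is hydrogen in place of cyclopropyl on a saturated chain carbon bound to an oxygen on an aromatic ring and reads in words as hydrogen in place of cyclopropyl on a saturated chain carbon bound to an oxygen on an aromatic ring, turning cyclopropylmethoxy into methoxy.

Among the compounds with values here, only one measured step changes a single place: a 1.7-fold lower number from compound 2 to compound 3 (0.22 log units; within the scatter) for difluoromethyl in place of methyl on an oxygen on an aromatic ring. That exchange is a different one and bears only indirectly, as a single change on a group bound to an oxygen on an aromatic ring that stayed within the scatter. Within the data shown here, no measured step covers the loss of cyclopropyl, so the data fix no direction.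

The step expected in this assay is a 1.1-fold higher number from compound 2 to compound 4 (0.06 log units; within the scatter) and no change beyond the scatter is expected. For compound 4 the estimated value is 12000 nM with an expected range of 5000 nM to 28000 nM.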

Compound 4, concentration for 50% growth inhibition: > 100000 nM
Compound 4 was reported as a limit (the forecaster's own chance of this, stated with the estimate: 8%); middle value at least 8.3-fold (0.92 log units) away from the limit.
By their numbers in this assay, from the lowest: compounds 3 and 2 (each within the scatter of the next); then compound 1. At a limit, above all of these: compound 4.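

Cyclopropylmethoxy to methoxy is the first single change in this series to move the number beyond the scatter, with the loss of cyclopropyl on a saturated chain carbon bound to an oxygen on an aromatic ring giving an at least 9.5-fold higher number from compound 2 to compound 4 (0.97 log units; beyond the scatter). In this assay, compound 4 stands as a limit and not as a number, which leaves the step with a lower bound only: the limit of > 100000 nM in this assay, at which 1 of the 4 values shown sits. The earlier single change, difluoromethyl in place of methyl on an oxygen on an aromatic ring, stayed within the scatter (a 1.7-fold lower number from compound 2 to compound 3 (0.22 log units; within the scatter)), so this position is the only place in the compounds shown where one exchange separates a measurable number from a limit.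

The pair does not tell whether the three-membered ring itself matters or only the 3 heavy atoms that leave with it; an ethyl, a propyl or a cyclobutylmethyl in place of cyclopropylmethyl would separate these readings. Also open, going by these compounds, is how a longer chain ending in an amine or a carboxylic acid would read at this place.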